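Cyanoamidine series: lipophilicity, isopropyl to ethyl on nitrogen

A few compounds are considered here, and "the series" means these few. Any claim that something is new, unique, unknown or untested is made for them only; others in the source may bear on it.

Measured compounds in a physicochemical assay for lipophilicity, read by HPLC, using the shake flask method; on this read-out higher numbers stand for higher lipophilicity and lower numbers for lower lipophilicity:
compound 1 `C/C(=N\C#N)N(Cc1ccc(Cl)nc1)C(C)C` gives 1.46
compound 2 `CCCC/C(=N\C#N)N(C)Cc1ccc(Cl)nc1` gives 1.87
compound 3 `CN(Cc1ccc(Cl)nc1)/C(=N/C#N)c1ccccc1` gives 1.86

Compound 1 stands lowest of the three numbers in this assay. The nearest is compound 3, and the furthest is compound 2, both beyond the scatter above compound 1, while compound 2 and compound 3 sit within the scatter of each other.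

The only step shown between measured compounds is a number 0.01 log units lower from compound 2 to compound 3 (within the scatter), which concerns the group on the carbon with a double bond to nitrogen and says nothing about the group on the amine nitrogen.

Compound 4 `CCN(Cc1ccc(Cl)nc1)/C(C)=N/C#N` differs from compound 1 by hydrogen in place of methyl on a saturated chain carbon bound to an amine nitrogen and a saturated chain carbon. Among the measured compounds shown here, no measured pair shows the effect of removing a methyl from that position, so the expectation rests on the general trend that losing a saturated carbon lowers this kind of read-out by a small amount.

Compound 4 is therefore expected to give 1.1 in this assay, in the range 0.75 to 1.45. This estimate means a step of a number 0.36 log units lower from compound 1 to compound 4 (beyond the scatter), expected to be downward and near the edge of the scatter.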

Compound 4, partition coefficient: 1.19
Compound 4: the middle estimate sits 0.09 log units below what was measured; the measured number falls inside the stated range.
By their numbers in this assay, from the lowest: compounds 4 and 1 (each within the scatter of the next); then compounds 3 and 2 (each within the scatter of the next).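

In this assay, among the compounds shown here, the exchange of isopropyl to ethyl gives a number 0.27 log units lower from compound 1 to compound 4 (within the scatter), the first step that reads this position on the amine nitrogen side; the one earlier step concerned only the group on the carbon with a double bond to nitrogen. Replacing methyl with hydrogen at this saturated chain carbon, a loss of one carbon, therefore cannot be told apart from repeat measurement on this read-out. No supporting data bear on the reason for this result.

From the compounds shown here alone, whether a longer chain or a hydroxyethyl group at this position would give a step beyond the scatter remains open. Going by these compounds, with a single pair available, it is also open whether the same exchange would read alike with butyl or phenyl on the carbon with a double bond to nitrogen.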